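Sulfonylated benzohydrazides: an acyl replaces an aryl on the hydrazide

A few compounds are considered here, and "the series" means these few. Any claim that something is new, unique, unknown or untested is made for them only; others in the source may bear on it.

Three sulfonamide hydrazides have been measured in a functional assay on OVCAR-3 cells (Homo sapiens) for antiproliferative activity, read by MTT assay, with a stated time of 24 h; on this read-out higher numbers stand for weaker inhibition and lower numbers for stronger inhibition. Compound 1 `O=C(NNc1ccccc1F)c1ccc(NS(=O)(=O)c2cnc(O)nc2O)cc1` carries an aryl on the terminal hydrazide nitrogen. Compound 2 `Cc1cccc(NNC(=O)c2ccccc2NS(=O)(=O)c2cnc(O)nc2O)c1` differs in the placement of the sulfonamide and in a 3-methylphenyl on that nitrogen. Compound 3 `O=C(NNC(=O)c1ccccc1F)c1cccc(NS(=O)(=O)c2cnc(O)nc2O)c1` instead carries a (2-fluorophenyl)carbonyl there, making a diacyl hydrazide.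

In this assay compound 2 gives > 20000 nM, which is a limit of the assay and not a number. Compound 1 likewise gives > 20000 nM, again a limit. Only compound 3, at 10800 nM, gives a number, and it is modest; the limit of > 20000 nM in this assay, at which 2 of the 3 values shown sit, describes the standing of the other two.

Compound 4 `O=C(NNC(=O)c1ccccc1NS(=O)(=O)c1cnc(O)nc1O)c1ccc(F)cc1` is not yet measured. It differs from compound 2 by (4-fluorophenyl)carbonyl in place of 3-methylphenyl on an amine nitrogen, so that compound 4, like compound 3, is a diacyl hydrazide. Among the measured compounds shown here, no step between measured compounds maps this change, so its size is open. The one measured diacyl hydrazide, compound 3, sits just inside the measurable range at 10800 nM, and a small gain of that order is expected for compound 4, so that the step from compound 2 to compound 4 is estimated as an at least 1.4-fold lower number from compound 2 to compound 4 (0.15 log units; that floor lies within the scatter). Compound 4 is therefore expected to give about 14000 nM, with a range of 6000 nM to 30000 nM; a result reported only as a limit remains a fair possibility.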

Compound 4, half-maximal inhibitory concentration: 15100 nM
Beside the measured number, compound 4's estimate is 1.1-fold (0.03 log units) below it, and the stated range covers the measured number.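

In this assay compound 4 shows that the amine nitrogen of compound 2, whose other neighbour is an amide-type nitrogen, can carry (4-fluorophenyl)carbonyl in place of 3-methylphenyl and still give a value inside the measurable range. Compound 2 stands at > 20000 nM, a limit of the assay and not a number. The change gives an at least 1.3-fold lower number from compound 2 to compound 4 (0.12 log units; that floor lies within the scatter), and only this floor can be read, not the full size of the step: the limit of > 20000 nM in this assay, at which 2 of the 4 values shown sit.

The change replaces an aryl with an acyl and brings in fluorine in a single step, so the compounds shown do not separate the contribution of the carbonyl from that of the fluorine, a question that an unsubstituted benzoyl or a (3-methylphenyl)carbonyl on the same nitrogen would address. As far as these compounds go, it also remains open whether a small aliphatic acyl such as acetyl, a longer chain or a carboxylic acid at this nitrogen would keep the value within the measurable range of this assay.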